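The source may report more compounds than this note shows. Statements on the series, on what has been measured and on what is new or still open speak of the compounds shown alone.

In an in vitro ADME assay on microsomes from liver (Rattus norvegicus) for metabolic stability (a higher number here means that the compound lasts longer, a lower number that the compound disappears faster), compound 1 (`COCCN1CC[C@H](C)Nc2cc(ccc2C(N)=O)-n2c(c(C)c3c2CC(C)(C)CC3=O)CC1=O`) gives > 0.5 h, and this is a limit of the assay rather than a number. Compound 2 (`CC(=O)NCC(=O)N1CCc2c(C)c3c(n2-c2ccc(C(N)=O)c(c2)N[C@@H](C)CC1)CC(C)(C)CC3=O`) gives > 0.5 h, which is also a limit. Within the data shown here, the whole record so far is therefore (the limit of > 0.5 h in this assay, at which 2 of the 2 values shown sit), so neither compound has an exact half-life and no measured step is available to guide a prediction.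

The next compound, compound 3 (`Cc1c2c(n3c1CC(=O)NCC[C@H](C)Nc1cc-3ccc1C(N)=O)CC(C)(C)CC2=O`), keeps the core of compound 1 but has hydrogen in place of 2-methoxyethyl on an amide-type nitrogen in a ring. Among the measured compounds shown here, this removes the side chain entirely, and the data contain no measured example of such a swap. For the measured compounds named here, with so little to go on, the expectation in this assay rests on the one limit shared by compound 1 at > 0.5 h and compound 2 at > 0.5 h, and no change beyond the usual scatter is expected in either direction. The estimated step, a step that the limit leaves unreadable from compound 1 to compound 3, should be read in that light. The half-life expected for compound 3 is 0.7 h, within an estimated range of 0.35 h to 1.4 h.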

Compound 3, half-life: > 0.5 h
Compound 3 was reported as a limit; the forecaster's own chance of this, stated with the estimate: 70%; the middle value does not contradict the limit.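

Compound 3, like compound 1, is reported only as a limit in this assay, so no step can be read between these two compounds: the limit of > 0.5 h in this assay, at which 3 of the 3 values shown sit.

The compounds shown leave open how long each one actually lasts, and whether hydrogen in place of 2-methoxyethyl on the amide-type nitrogen in a ring changes the half-life at all.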